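This account rests on a few compounds, and the source may have more. Where it says the series, first, only, none or still open, it means among the compounds named here.

Compound 1 `C=C(CC)C(=O)c1ccc(OCC(=O)Nc2ccc(C(N)=O)cc2)c(Cl)c1Cl`: 3700 nM
Compound 2 `C=C(CC)C(=O)c1ccc(OCC(=O)Nc2ccc(O)cc2)c(Cl)c1Cl`: 6400 nM
Compound 3 `C=C(CC)C(=O)c1ccc(OCC(=O)Nc2ccc(C(=O)O)cn2)c(Cl)c1Cl`: 14900 nM

In a functional assay on CLL cells (Homo sapiens) for cytotoxicity, read by MTT assay, with a stated time of 48 h (a lower number here means that less compound is needed, a higher number that more compound is needed for the effect), compound 3 gives the highest of the three numbers, as the steps of a 4.0-fold higher number from compound 1 to compound 3 (0.60 log units; beyond the scatter) and a 2.3-fold higher number from compound 2 to compound 3 (0.37 log units; beyond the scatter) show, while a 1.7-fold higher number from compound 1 to compound 2 (0.24 log units; within the scatter). Compound 4 `C=C(CC)C(=O)c1ccc(OCC(=O)NCO[N+](=O)[O-])c(Cl)c1Cl` differs from compound 3 in one place: (nitrooxy)methyl in place of 5-carboxypyridin-2-yl on an amide-type nitrogen. Going by the values given here, no measured step trades the aromatic group on the amide-type nitrogen for a group without a ring, so the measured steps bear on this change only loosely; they show that swapping this group shifted the number by modest amounts at most. Among the compounds with values here, a modest move toward a lower number is therefore expected, a 2.1-fold lower number from compound 3 to compound 4 (0.33 log units; beyond the scatter), with a wide range because no direct precedent exists. Compound 4 is expected to give 7000 nM, within a range from 2500 nM to 20000 nM.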

Compound 4, half-maximal effective concentration: 4100 nM
Compound 4: the middle estimate sits 1.7-fold (0.23 log units) above what was measured; the range from low to high includes it.
By their numbers in this assay, from the lowest: compounds 1, 4 and 2 (each within the scatter of the next); then compound 3.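

In this assay a ring on the amide-type nitrogen proves unnecessary for a number in this range: (nitrooxy)methyl, which has no ring, gives a 3.6-fold lower number from compound 3 to compound 4 (0.56 log units; beyond the scatter) and stays within the scatter of the two ring-bearing phenyl compounds, with a 1.6-fold lower number from compound 2 to compound 4 (0.19 log units; within the scatter) and a 1.1-fold higher number from compound 1 to compound 4 (0.04 log units; within the scatter) as the steps. Among these four compounds, only the one bearing 5-carboxypyridin-2-yl stands apart. Nothing measured here explains this result. Going by these compounds, it remains open whether the nitrooxy part matters, since a plain methyl, a longer chain or a chain ending in an amine could separate its contribution from that of removing the ring.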